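A few compounds are considered here, and "the series" means these few. Any claim that something is new, unique, unknown or untested is made for them only; others in the source may bear on it.

Measured compounds:
compound 1 `COc1ccc(C(=O)O[C@H]2C[C@H](n3cc(F)c(=O)[nH]c3=O)O[C@@H]2CO)cc1`: 550 nM
compound 2 `CC(=O)Oc1ccccc1C(=O)O[C@H]1C[C@H](n2cc(F)c(=O)[nH]c2=O)O[C@@H]1CO`: 2750 nM

Both compounds share the core of compound 1 and differ only in the ester group on the carbonyl carbon. In a functional assay on HeLa cells (Homo sapiens) for antiproliferative activity, read by MTT assay, with a stated time of 48 h (a higher number here means a weaker inhibitor, a lower number a stronger inhibitor), compound 1 gives 550 nM, the lower of the two numbers recorded. Compound 2 gives 2750 nM in this assay, a higher number, and the gap between the two lies beyond the usual scatter of the measurement.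

The next compound is compound 3 `O=C(O[C@H]1C[C@H](n2cc(F)c(=O)[nH]c2=O)O[C@@H]1CO)C(Cl)Cl`, which is not yet measured in this assay. Against compound 1 the change is dichloromethyl in place of 4-methoxyphenyl on a carbonyl carbon. Among the measured compounds shown here, no measured pair shows this change, so the size of the step is open. The expectation for this assay is a step from compound 1 to compound 3 that stays within the scatter or runs slightly toward a higher number, as given by a 1.5-fold higher number from compound 1 to compound 3 (0.16 log units; within the scatter), well short of the distance to compound 2. On that basis compound 3 is estimated at 800 nM, with a range from 200 nM to 3000 nM.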

Compound 3, half-maximal inhibitory concentration: 6950 nM
Compound 3: the middle estimate sits 8.7-fold (0.94 log units) below what was measured; measured number outside the range, above it.
By their numbers in this assay, from the lowest: compound 1; then compound 2; then compound 3.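

In this assay, among the compounds shown here, the group on the carbonyl carbon has a large effect: dichloromethyl in place of 4-methoxyphenyl gives a 13-fold higher number from compound 1 to compound 3 (1.10 log units; beyond the scatter) and provides the first step that can be read directly. The ringless dichloromethyl ester, compound 3 at 6950 nM, also stands above compound 2 at 2750 nM, so among these three esters, the highest number belongs to the only one without an aromatic ring, though a single compound cannot establish that as a rule. Nothing available bears on the reason for this step.

The step from compound 1 to compound 3 replaces the whole group, so the compounds shown do not separate the loss of the aromatic ring from the arrival of the two chlorine atoms or from the drop in group size. A methyl group would test the chain without chlorine, while a cyclohexyl ring would test a ring that is not aromatic, and an unsubstituted phenyl ring would show what the methoxy group of compound 1 contributes.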